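Phenyl for Iodo on a Shared Nucleoside Core

The source may hold more compounds than are shown below. What is called first, only, known or untested is meant among the compounds shown, and "the series" means these compounds.

Compound 1 `Cc1nc(N)c2c(-c3ccccc3)cn([C@@H]3O[C@H](CO)[C@@H](O)[C@H]3O)c2n1` — > 20000 nM
Compound 2 `Cc1nc(N)c2c(I)cn([C@@H]3O[C@H](CO)[C@@H](O)[C@H]3O)c2n1` — 9030 nM
Compound 3 `CNc1ncnc2c1c(I)cn2[C@@H]1O[C@H](CO)[C@@H](O)[C@H]1O` — > 100000 nM

The three measured compounds were tested in a functional assay on CCRF-CEM cells (Homo sapiens), read by MTT assay, with a stated time of 72 h; on this read-out lower numbers stand for stronger inhibition and higher numbers for weaker inhibition. Compound 2 gives 9030 nM. Compound 1 gives only a limit, > 20000 nM, which is the limit (the limit of > 20000 nM in this assay, at which 1 of the 3 values shown sits). The change from compound 2 to compound 1 is phenyl in place of iodo on an aromatic carbon, and it produced an at least 2.2-fold higher number from compound 2 to compound 1 (0.34 log units; beyond the scatter).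

Compound 3 gives only a limit, > 100000 nM, which is the limit (the limit of > 100000 nM in this assay, at which 1 of the 3 values shown sits). Compound 3 and compound 2 are built of the same atoms joined differently; the difference between the two cores is not broken down here.

Compound 4 `CNc1ncnc2c1c(-c1ccccc1)cn2[C@@H]1O[C@H](CO)[C@@H](O)[C@H]1O` has not yet been measured in this assay. It differs from compound 3 by phenyl in place of iodo on an aromatic carbon, the same change that separates compound 2 from compound 1, with the place of the change described in the same words.

An expectation for compound 4 therefore rests on two things: the starting point, compound 3, already sits at the limit of > 100000 nM in this assay, at which 1 of the 3 values shown sits, with > 100000 nM, and the same change weakened inhibition when it went from compound 2 to compound 1 by an at least 2.2-fold higher number from compound 2 to compound 1 (0.34 log units; beyond the scatter). Compound 4 is thus expected to show a step that the limit leaves unreadable from compound 3 to compound 4 from its parent, that is, to remain at or beyond the limit rather than giving a number. The estimate for compound 4 in this assay is 300000 nM, within 100000 nM to 3000000 nM.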

Compound 4, half-maximal inhibitory concentration: > 20000 nM
Compound 4: no number, only a limit (the forecaster's own chance of this, stated with the estimate: 95%); the middle value does not contradict the limit.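

In this assay compound 4 gives > 20000 nM as a limit, not a number. Compound 3 also gives > 100000 nM as a limit, not a number. With only limits on both sides, the step from compound 3 to compound 4 cannot be read. The compounds shown leave open how far phenyl in place of iodo shifts inhibition on the core of compound 3.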